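The source may report more compounds than this note shows. Statements on the series, on what has been measured and on what is new or still open speak of the compounds shown alone.

Measured in a toxicity assay on HepG2 2.2.15 cells (Homo sapiens) for cytotoxicity, read by CellTiter-Glo; on this read-out lower numbers stand for higher toxicity in this test and higher numbers for lower toxicity in this test:
- compound 1 `O=C1CC(C(F)(F)F)CN1c1cnn2c1CN(C(=O)Nc1cc(F)c(F)c(F)c1)C(C1CC1)C2`: 115000 nM
- compound 2 `C[C@H]1Cn2ncc(N3CC(c4ccccc4)CC3=O)c2CN1CC(=O)Nc1cc(F)c(F)c(F)c1`: > 2000 nM, a limit of the assay
- compound 3 `C[C@H]1Cn2ncc(N3CC(c4ccccc4)CC3=O)c2CN1C(=S)Nc1cc(F)c(F)c(F)c1`: > 2000 nM, a limit of the assay

Within the data shown here, compound 1 holds the only actual number in this set, as the other two entries are limits and not numbers. Compound 4 `O=C1CC(c2ncco2)CN1c1cnn2c1CN(C(=O)Nc1cc(F)c(F)c(F)c1)C(C1CC1)C2` keeps the core of compound 1 and differs from it in one place: 1,3-oxazol-2-yl in place of trifluoromethyl on a saturated ring carbon. There, 1,3-oxazol-2-yl stands in place of trifluoromethyl on a saturated ring carbon. Among the measured compounds shown here, no measured step covers this change, so the expectation rests on compound 1 at 115000 nM alone, and no step beyond the scatter is expected in this assay. The expected change is a 1.4-fold lower number from compound 1 to compound 4 (0.16 log units; within the scatter). For compound 4 the estimated value is 80000 nM, with an expected range of 20000 nM to 200000 nM.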

Compound 4, half-maximal cytotoxic concentration: > 200000 nM
Compound 4 was reported as a limit; the forecaster's own chance of this, stated with the estimate: 40%; at least 2.5-fold (0.39 log units) between middle value and limit.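

In this assay, 1,3-oxazol-2-yl in place of trifluoromethyl on a saturated ring carbon gives an at least 1.7-fold higher number from compound 1 to compound 4 (0.24 log units; that floor lies within the scatter). Compound 4 carries a limit and not a number: the limit of > 200000 nM in this assay, at which 1 of the 4 values shown sits. This shows that the position can carry a five-membered aromatic ring with 2 hetero atoms without a lower number appearing, which compound 1 alone could not show. From the compounds shown here alone, how far compound 4 truly lies from compound 1 stays open, as does whether an amine or a carboxylic acid on this ring carbon would give a lower number.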